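Extending a methoxy group to allyloxy on the shared core

The source may report more compounds than this note shows. Statements on the series, on what has been measured and on what is new or still open speak of the compounds shown alone.

Of the compounds shown here, three of the same core have been measured in an assay for inhibition of 3-hydroxy-3-methylglutaryl-coenzyme A reductase (Rattus norvegicus); a higher number here means a weaker inhibitor, a lower number a stronger inhibitor. Compound 1 `C=C(C)CO[C@H]1C[C@@H](C)C=C2C=C[C@H](C)[C@H](CCC3C[C@@H](O)CC(=O)O3)[C@H]21` gives 360 nM. Compound 2 `CO[C@H]1C[C@@H](C)C=C2C=C[C@H](C)[C@H](CCC3C[C@@H](O)CC(=O)O3)[C@H]21` gives 2810 nM, and compound 3 `C[C@H]1C=C2C=C[C@H](C)[C@H](CCC3C[C@@H](O)CC(=O)O3)[C@H]2[C@@H](OCc2ccccc2)C1` gives 27 nM. Compound 2 thus has the highest number of the three, with a 100-fold lower number from compound 2 to compound 3 (2.02 log units; beyond the scatter) and, read in the other direction, a 7.8-fold higher number from compound 1 to compound 2 (0.89 log units; beyond the scatter).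

Compound 4 `C=CCO[C@H]1C[C@@H](C)C=C2C=C[C@H](C)[C@H](CCC3C[C@@H](O)CC(=O)O3)[C@H]21` is not yet measured. It differs from compound 2 by vinyl in place of hydrogen on a saturated chain carbon bound to an oxygen on a saturated carbon. For the measured compounds named here, two measured steps bear on this change, both leaving the same hydrogen at the same place: a 100-fold lower number from compound 2 to compound 3 (2.02 log units; beyond the scatter) and a 7.8-fold higher number from compound 1 to compound 2 (0.89 log units; beyond the scatter), the latter meaning that removing the 1-methylethenyl group raised the number. Every replacement of this hydrogen by a carbon group seen so far has lowered the number well beyond the scatter, so a vinyl group is expected to do the same. Since vinyl is the smaller of the groups tried, its effect is expected to fall somewhat short of that of the 1-methylethenyl group, though in the same direction. The step is accordingly estimated as a 5.1-fold lower number from compound 2 to compound 4 (0.71 log units; beyond the scatter). Compound 4 is therefore expected to give about 550 nM, within a range from 200 nM to 1500 nM.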

Compound 4, half-maximal inhibitory concentration: 370 nM
Compound 4: the middle estimate sits 1.5-fold (0.17 log units) above what was measured; measured number inside the range.
By their numbers in this assay, from the lowest: compound 3; then compounds 1 and 4 (each within the scatter of the next); then compound 2.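

In this assay the change from methoxy to allyloxy brings a 7.6-fold lower number from compound 2 to compound 4 (0.88 log units; beyond the scatter) and this shows that vinyl, the smallest carbon group tried on this carbon, is already enough for a clear step away from the plain methoxy compound. Hydrogen in place of methyl on the double-bonded chain carbon gives a 1.0-fold higher number from compound 1 to compound 4 (0.01 log units; within the scatter) and so, at this level of measurement, the allyl and 2-methylallyl side chains cannot be told apart, which means that this extra methyl makes no visible difference. Vinyl in place of phenyl gives a 14-fold higher number from compound 3 to compound 4 (1.14 log units; beyond the scatter) and so a carbon group on this position is not enough by itself to match the phenyl compound: which group enters matters, not only that one does.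

The compounds shown leave open whether a saturated propyl chain would match allyl, and whether a longer chain or a phenyl group carrying an amine would move the number further. Nothing available here explains any of these steps.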